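Opening a ring: a fluorinated chain replaces the cyclobutyl

A few compounds are considered here, and "the series" means these few. Any claim that something is new, unique, unknown or untested is made for them only; others in the source may bear on it.

Measured so far:
compound 1, `CCCCC1([C@H](O)/C=C/[C@H]2COC(=O)N2CCSc2nc(C(=O)O)cs2)CCC1`, 220 nM
compound 2, `CC(C)(C)CCC1([C@H](O)/C=C/[C@H]2COC(=O)N2CCSc2nc(C(=O)O)cs2)CCC1`, 149 nM

In an assay on isolated protein for binding affinity to prostaglandin E2 receptor EP1 subtype (Homo sapiens) (a higher number here means a weaker inhibitor, a lower number a stronger inhibitor), compound 2 gives the lower of the two numbers, yet the gap to compound 1 is small: a 1.5-fold lower number from compound 1 to compound 2 (0.17 log units; within the scatter). Compound 3, `CC(C)(CCCCF)[C@H](O)/C=C/[C@H]1COC(=O)N1CCSc1nc(C(=O)O)cs1`, has not been measured. It differs from compound 2 in one place: 5-fluoro-1,1-dimethylpentyl in place of 1-(3,3-dimethylbutyl)cyclobutyl on a saturated chain carbon bound to a double-bonded chain carbon and an oxygen on a saturated carbon. For the measured compounds named here, the only measured step concerns a change farther out on that same group, swapping a small for a larger branch, and it stayed within the scatter. Nothing measured speaks to removing the four-membered ring or to adding a fluorine at the end of a chain, so for compound 3 the step is expected only loosely as a 2.0-fold higher number from compound 2 to compound 3 (0.30 log units; within the scatter), its direction is uncertain, and a step beyond the scatter in either sense is possible. Compound 3 is therefore expected to give about 300 nM in this assay, within a wide range from 70 nM to 1300 nM.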

Compound 3, inhibition constant: 431 nM
Estimate against measurement, compound 3: 1.4-fold (0.16 log units) below, and the stated range covers the measured number.
By their numbers in this assay, from the lowest: compounds 2, 1 and 3 (each within the scatter of the next, the first and the last beyond it).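

In this assay, for the compounds shown here, putting 5-fluoro-1,1-dimethylpentyl in place of 1-(3,3-dimethylbutyl)cyclobutyl gives a 2.9-fold higher number from compound 2 to compound 3 (0.46 log units; beyond the scatter) and is the only step here beyond the scatter, so the group at this position can shift the number measurably. Set against 1-butylcyclobutyl, the same group gives a 2.0-fold higher number from compound 1 to compound 3 (0.29 log units; within the scatter) and so cannot be told apart from it, which makes the loss modest and dependent on the comparison. Nothing available here explains the shift.

Going by these compounds, the four-membered ring leaves and the fluorine enters in one step, so their separate contributions remain open. A 1,1-dimethylpentyl group without the fluorine, or a 1-(4-fluorobutyl)cyclobutyl group that keeps the ring, would be the comparisons needed to pull the two changes apart.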